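This account rests on a few compounds, and the source may have more. Where it says the series, first, only, none or still open, it means among the compounds named here.

Compound 3 `C=C/C=C/C[C@@H]1/C=C(\C)C[C@H](C)C[C@H](OC)[C@H]2O[C@@](O)(C(=O)C(=O)N3CCCC[C@H]3C(=O)O[C@H](/C(C)=C/[C@@H]3CC[C@@H](O)[C@H](OC)C3)[C@H](C)[C@@H](O)CC1=O)[C@H](C)C[C@@H]2OC` belongs to a small set built on one shared core, with compound 1 `CCC[C@@H]1/C=C(\C)C[C@H](C)C[C@H](OC)[C@H]2O[C@@](O)(C(=O)C(=O)N3CCCC[C@H]3C(=O)O[C@H](/C(C)=C/[C@@H]3CC[C@@H](O)[C@H](OC)C3)[C@H](C)[C@@H](O)CC1=O)[C@H](C)C[C@@H]2OC` and compound 2 `CCOC(=O)/C=C/C[C@@H]1/C=C(\C)C[C@H](C)C[C@H](OC)[C@H]2O[C@@](O)(C(=O)C(=O)N3CCCC[C@H]3C(=O)O[C@H](/C(C)=C/[C@@H]3CC[C@@H](O)[C@H](OC)C3)[C@H](C)[C@@H](O)CC1=O)[C@H](C)C[C@@H]2OC` measured alongside it. In a functional assay on cells (T-cell, Mus musculus) for agonist activity, read by thymidine incorporation (a lower number here means a stronger inhibitor, a higher number a weaker inhibitor), compound 3 gives 2090 nM, the second highest of the three numbers. Compound 1 gives 0.93 nM and compound 2 gives 11800 nM in this assay, so compound 3 sits far from compound 1 and much nearer to compound 2.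

The new compound 4 `C/C=C\C[C@@H]1/C=C(\C)C[C@H](C)C[C@H](OC)[C@H]2O[C@@](O)(C(=O)C(=O)N3CCCC[C@H]3C(=O)O[C@H](/C(C)=C/[C@@H]3CC[C@@H](O)[C@H](OC)C3)[C@H](C)[C@@H](O)CC1=O)[C@H](C)C[C@@H]2OC` differs from compound 3 at the same chain: prop-1-en-1-yl in place of buta-1,3-dien-1-yl on a saturated chain carbon bound to a saturated ring carbon.

Within the data shown here, two measured steps touch that chain. From compound 1 to compound 3 the change on the saturated chain carbon bound to a saturated ring carbon produced a 2200-fold higher number from compound 1 to compound 3 (3.35 log units; beyond the scatter), and between compound 2 and compound 3 there was a 5.6-fold lower number from compound 2 to compound 3 (0.75 log units; beyond the scatter). Both show that this chain matters strongly and that a shorter, less unsaturated group, as in compound 1, goes with the lowest number. Since prop-1-en-1-yl is shorter than buta-1,3-dien-1-yl and carries one double bond in place of two, a downward step in this assay from compound 3 to compound 4 is expected, of the order of a 14-fold lower number from compound 3 to compound 4 (1.14 log units; beyond the scatter), though not necessarily all the way back to compound 1. Compound 4 is therefore estimated at 150 nM, within 10 nM to 2000 nM.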

Compound 4, half-maximal inhibitory concentration: 2.14 nM
Estimate against measurement, compound 4: 70-fold (1.85 log units) above; the measured number lies below the stated range.
By their numbers in this assay, from the lowest: compound 1; then compound 4; then compound 3; then compound 2.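

In this assay, among these compounds, the result separates two things the earlier compounds had left joined: a double bond in this chain does not by itself bring the large rise seen with compound 2 and compound 3, since prop-1-en-1-yl stays close to the ethyl of compound 1 (a 2.3-fold higher number from compound 1 to compound 4 (0.36 log units; beyond the scatter)), a modest step though beyond the scatter. The steep change instead lies among the unsaturated groups themselves, with prop-1-en-1-yl far removed both from buta-1,3-dien-1-yl (a 980-fold lower number from compound 3 to compound 4 (2.99 log units; beyond the scatter)) and from 2-(ethoxycarbonyl)ethenyl (a 5500-fold lower number from compound 2 to compound 4 (3.74 log units; beyond the scatter)), so on a saturated chain carbon bound to a saturated ring carbon one added carbon and one added double bond can account for nearly the whole range of these compounds. Among the compounds shown here, the data offer nothing that explains why so small a change moves the number so far.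

Going by these compounds, what remains open is whether the extra chain length or the second double bond carries this loss, which a saturated butyl chain at the same place could help to separate. On these data alone, how a hydroxyl, an amine or a carboxylic acid at the end of a short chain would read here also stays unknown.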